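Urea Aryl Variation on a Pyrazole Core: Compound 4

This account rests on a few compounds, and the source may have more. Where it says the series, first, only, none or still open, it means among the compounds named here.

Measured so far in a functional assay on HCT-116 cells (Homo sapiens) for inhibition, read by sulforhodamine B assay, with a stated time of 48 h, tested at 0.01 uM; on this read-out lower numbers stand for a stronger effect and higher numbers for a weaker effect at the one concentration tested:
compound 1, `COc1cc(Cl)cc(-c2nn(-c3cccc(NC(=O)Nc4ccc(Cl)c(C(F)(F)F)c4)c3)cc2-c2ccncc2)c1`, 104%
compound 2, `COc1cc(Cl)cc(-c2nn(-c3cccc(NC(=O)Nc4cc(C(F)(F)F)cc(C(F)(F)F)c4)c3)cc2-c2ccncc2)c1`, 102%
compound 3, `COc1cc(Cl)cc(-c2nn(-c3cccc(NC(=O)Nc4ccc(Cl)c(Cl)c4)c3)cc2-c2ccncc2)c1`, 105%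

Compound 3 carries the highest of the three numbers, but its nearest neighbour, compound 1, lies only a number 1 percentage points higher from compound 1 to compound 3 (within the scatter) away, and compound 2 is within the scatter as well, so none of the three can be placed above another. Every number sits close to an unchanged signal at the single concentration tested.

Compound 4, `COc1cc(Cl)cc(-c2nn(-c3cccc(NC(=O)Nc4cccc(C(F)(F)F)c4)c3)cc2-c2ccncc2)c1`, has not yet been measured. It differs from compound 3 in one place: 3-(trifluoromethyl)phenyl in place of 3,4-dichlorophenyl on an amide-type nitrogen. Within the data shown here, the only measured step touching the same aryl ring is the one from compound 1 to compound 3, which moved the read-out by a number 1 percentage points higher from compound 1 to compound 3 (within the scatter), within the scatter. Compound 2, with a further variation of the same ring, also gives a number within the scatter of the others. With every step among these variations so far lying within the scatter, the expected step from compound 3 to compound 4 is a number 2 percentage points lower from compound 3 to compound 4 (within the scatter), no change beyond the scatter in either direction. For compound 4 the expected value is 103%, between 95% and 111%.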

Compound 4, a percentage reported as activity, at one concentration (the size of the read-out at that concentration, not a potency): 101%
The estimate for compound 4 lay 2 percentage points above the measured number; measured number inside the range.
By their numbers in this assay, from the lowest: compounds 4, 2, 1 and 3 (each within the scatter of the next).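

In this assay, the change on the amide-type nitrogen from 3,4-dichlorophenyl to 3-(trifluoromethyl)phenyl gives a number 4 percentage points lower from compound 3 to compound 4 (within the scatter) and stays inside the range of the other variations. Among these compounds, compound 4 also shows what the earlier compounds did not: with only one group left on this ring, the read-out still does not separate, whether trifluoromethyl gives way to hydrogen, with a number 1 percentage points lower from compound 2 to compound 4 (within the scatter), or chloro gives way to hydrogen, with a number 3 percentage points lower from compound 1 to compound 4 (within the scatter) and no trend among the four compounds. No available evidence bears on why these compounds stay together.

As far as these compounds go, what an amine or a carboxylic acid on this ring would do remains open. Also open is whether these four compounds would separate at any concentration other than the single one shown.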